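The source may hold more compounds than are shown below. What is called first, only, known or untested is meant among the compounds shown, and "the series" means these compounds.

Measured compounds:
compound 1, `COc1ccc([C@H]2OC[C@H]([C@@H](O)c3ccc(OC)c(OC)c3)C[C@@H]2C/C=C/c2ccccc2)cc1OC` — 14800 nM
compound 2, `Oc1ccc(/C=C/C[C@H]2C[C@@H]([C@@H](O)c3ccccc3)CO[C@@H]2c2ccccc2)cc1` — 14400 nM
compound 3, `O=[N+]([O-])c1ccc(/C=C/C[C@H]2C[C@@H]([C@@H](O)c3ccccc3)CO[C@@H]2c2ccccc2)cc1` — 12400 nM

All three were run in a functional assay on HeLa cells (Homo sapiens) for cytotoxicity, read by WST assay, with a stated time of 48 h; a higher number here means a weaker inhibitor, a lower number a stronger inhibitor. Compound 1 gives the highest of the three numbers shown, but neither its gap to compound 2 nor its gap to compound 3 exceeds the scatter, so nothing separates these compounds in this assay. Compound 2 and compound 3 differ only on the aromatic ring at the end of the chain, and that change gave a 1.2-fold lower number from compound 2 to compound 3 (0.06 log units; within the scatter).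

Compound 4, `COc1ccc(/C=C/C[C@H]2C[C@@H]([C@@H](O)c3ccc(OC)c(OC)c3)CO[C@@H]2c2ccc(OC)c(OC)c2)cc1OC`, is not yet measured. It differs from compound 1 by 3,4-dimethoxyphenyl in place of phenyl on a double-bonded chain carbon bound to a double-bonded chain carbon. For the measured compounds named here, the only measured step that touches the same part of the molecule is the one from compound 2 to compound 3, where exchanging one substituent on that ring for another left the number within the scatter. Beyond that, the values of compound 1 and compound 2, which differ in the other two aromatic rings, likewise sit within the scatter of each other. No step shown moves this assay beyond its scatter, so no shift beyond the scatter is expected for compound 4.

The number for compound 4 in this assay is therefore expected to be close to that of compound 1, with an expected step of a 1.1-fold lower number from compound 1 to compound 4 (0.02 log units; within the scatter). The estimate for compound 4 is 14000 nM, with a range from 6000 nM to 32000 nM.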

Compound 4, half-maximal inhibitory concentration: 23800 nM
Beside the measured number, compound 4's estimate is 1.7-fold (0.23 log units) below it, and the stated range covers the measured number.
By their numbers in this assay, from the lowest: compounds 3, 2, 1 and 4 (each within the scatter of the next).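

In this assay the exchange of phenyl for 3,4-dimethoxyphenyl on a double-bonded chain carbon bound to a double-bonded chain carbon gave a 1.6-fold higher number from compound 1 to compound 4 (0.21 log units; within the scatter), so this is a step in the series that adds to the terminal ring rather than swapping one ring substituent for another. The entering group has 10 heavy atoms against 6 and 2 hydrogen-bond acceptors against 0, yet the step stays within the scatter, so these added atoms do not separate compound 4 from compound 1 in this cytotoxicity read-out. No measurement is available that would explain this reading.

Going by these compounds, only phenyl, 3,4-dimethoxyphenyl and the hydroxy- and nitro-bearing rings stand at this place, and the hydroxy and nitro pair sit on a core with different groups on the other two aromatic rings, so it remains open whether the same exchange would read alike on that core. For the compounds shown here, also open is whether an amine or a carboxylic acid on this ring, or a longer chain ahead of it, would give any step beyond the scatter, since no step does so.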